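The source may report more compounds than this note shows. Statements on the series, on what has been measured and on what is new or still open speak of the compounds shown alone.

In a functional assay (lung) for inhibition, with Cavia porcellus as the target (on this read-out lower numbers stand for stronger inhibition and higher numbers for weaker inhibition), compound 3 (`c1cc(COc2ccc(-c3nn[nH]n3)cc2)cc(OCc2ccc3ccccc3n2)c1`) gives 14 nM and stands level, within the usual scatter, with compound 1 (`C(=C/c1cccc(-c2nn[nH]n2)c1)\c1cccc(OCc2ccc3ccccc3n2)c1`) at 20 nM on this read-out. Compound 2 (`O=C(O)c1ccc(COc2cccc(OCc3ccc4ccccc4n3)c2)cc1`) at 75 nM lies beyond the scatter on the side of weaker inhibition relative to compound 3. Compound 4 (`COc1cc(-c2nn[nH]n2)ccc1OCc1cccc(OCc2ccc3ccccc3n2)c1`) differs from compound 3 by a single change, methoxy in place of hydrogen on an aromatic carbon with methoxy in place of hydrogen on an aromatic carbon, ortho to a large group and meta to a 2H-tetrazol-5-yl group. Among the compounds with values here, no measured pair here isolates such a change, so its size cannot be read directly from the data. Compound 1 at 20 nM and compound 3 at 14 nM both carry the 2H-tetrazol-5-yl group and remain within the scatter of each other despite differing elsewhere, which gives modest grounds to expect that a small addition will be tolerated. The expected change is a 1.4-fold higher number from compound 3 to compound 4 (0.15 log units; within the scatter) and it is expected to stay within the scatter, leaning slightly towards weaker inhibition. Compound 4 is expected at 20 nM with an estimated range from 6 nM to 65 nM as a working expectation.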

Compound 4, half-maximal inhibitory concentration: 36 nM
Beside the measured number, compound 4's estimate is 1.8-fold (0.26 log units) below it; the measured number falls inside the stated range.
By their numbers in this assay, from the lowest: compounds 3, 1 and 4 (each within the scatter of the next, the first and the last beyond it); then compound 2.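

In this assay, methoxy in place of hydrogen on an aromatic carbon, ortho to a large group and meta to a 2H-tetrazol-5-yl group, gives a 2.6-fold higher number from compound 3 to compound 4 (0.41 log units; beyond the scatter). Within the data shown here, this single pair is the first direct reading of any change at this position, and it shows that even this small addition weakens inhibition by more than the usual scatter, though one step supports only a modest conclusion. Nothing in the data explains the size of this step.

From the compounds shown here alone, whether a fluorine or a hydroxyl at this position would give a step of similar size remains open. Also open, going by these compounds, is whether the same methoxy change would have a comparable effect on a compound carrying a carboxylic acid in place of the 2H-tetrazol-5-yl group.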